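This account rests on a few compounds, and the source may have more. Where it says the series, first, only, none or still open, it means among the compounds named here.

Compound 1 `Cc1cc(OCc2sc(-c3ccccc3)nc2C)ccc1OCC(=O)O` gives only a limit in an assay on CHO cells for agonist activity at Free fatty acid receptor 1 (Homo sapiens), read by FLIPR (a higher number here means that more compound is needed for the effect, a lower number that less compound is needed), namely > 10000 nM.
Compound 2 `Cc1nc(-c2ccccc2)sc1COc1ccc(OCC(=O)O)c(F)c1` gives 374 nM in this assay.
Compound 3 `Cc1nc(-c2cccc(F)c2)sc1COc1ccc(OCC(=O)O)c(F)c1` gives 185 nM in this assay.

Among the two numbers measured, compound 2 stands highest; its nearest neighbour is compound 3, reached by a 2.0-fold lower number from compound 2 to compound 3 (0.31 log units; beyond the scatter). The value of compound 1 is a limit only, (the limit of > 10000 nM in this assay, at which 1 of the 3 values shown sits), and cannot be ranked against the others.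

Compound 4 `Cc1cccc(-c2nc(C)c(COc3ccc(OCC(=O)O)c(F)c3)s2)c1` differs from compound 2 in one place: methyl in place of hydrogen on an aromatic carbon, a methyl in place of hydrogen on an aromatic carbon of the phenyl ring. Among the compounds with values here, two measured steps bear on this. The step of an at least 26-fold lower number from compound 1 to compound 2 (1.42 log units; beyond the scatter) is large, but it exchanges fluoro for methyl on the other aromatic ring of the shared core, not on the phenyl. Closer in kind is a 2.0-fold lower number from compound 2 to compound 3 (0.31 log units; beyond the scatter), which places fluoro in place of hydrogen on the phenyl and gives a modest gain. A methyl at the phenyl is therefore expected to move the number little, most likely downward by a modest amount, and possibly not beyond the scatter.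

For compound 4 the estimate is 250 nM, within a range from 100 nM to 700 nM, which corresponds to an expected step of a 1.5-fold lower number from compound 2 to compound 4 (0.17 log units; within the scatter).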

Compound 4, half-maximal effective concentration: 247 nM
For compound 4 the middle estimate is 1.0-fold (0.01 log units) above the measured one; the measured number falls inside the stated range.
By their numbers in this assay, from the lowest: compounds 3, 4 and 2 (each within the scatter of the next, the first and the last beyond it). At a limit, above all of these: compound 1.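

In this assay, within the data shown here, the change from phenyl to 3-methylphenyl gives a 1.5-fold lower number from compound 2 to compound 4 (0.18 log units; within the scatter), so at this carbon a methyl produces no step that can be told from the scatter. Methyl in place of fluoro at the same carbon gives a 1.3-fold higher number from compound 3 to compound 4 (0.13 log units; within the scatter), so the two groups are not separated here, although the fluoro step, a 2.0-fold lower number from compound 2 to compound 3 (0.31 log units; beyond the scatter), does lie beyond the scatter. The exchange of methyl and fluoro therefore counts for far more on the other aromatic ring, where one end of the comparison is a limit, than on this phenyl: the same change on two cores in this assay, an at least 26-fold lower number (1.42 log units; beyond the scatter) from compound 1 to compound 2 and a 1.3-fold lower number (0.13 log units; within the scatter) from compound 4 to compound 3, at least 20-fold (1.30 log units) apart, beyond the scatter of two such steps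

As far as these compounds go, whether this carbon would accept groups of another kind, such as methoxy, trifluoromethyl or an amine, stays open, as does whether other carbons of the phenyl would respond as this one does. The compounds shown also give no reason why the same exchange differs so much between the two rings.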